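Adding a Methyl Group to a Prostaglandin D2 Receptor Ligand

A few compounds are considered here, and "the series" means these few. Any claim that something is new, unique, unknown or untested is made for them only; others in the source may bear on it.

Measured compounds:
- compound 1, `Cc1cc(OC[C@@H]2CN(C)c3ccccc3O2)ccc1C(=O)n1c(C)c(CC(=O)O)c2cc(F)ccc21`: 2.7 nM
- compound 2, `Cc1cc(C(=O)n2c(C)c(CC(=O)O)c3cc(F)ccc32)ccc1OC[C@@H]1CN(C)c2ccccc2O1`: 59 nM

Both compounds were tested in an assay on CHO cells for displacement of a labelled ligand from prostaglandin D2 receptor (Mus musculus), read by scintillation counting, with a stated time of 20 min; on this read-out higher numbers stand for weaker inhibition and lower numbers for stronger inhibition. Compound 1 gives 2.7 nM in this assay, while compound 2 gives 59 nM. Of the two numbers, compound 2 stands at the higher one, so it is the weaker binder of this pair, and the gap between compound 1 and compound 2 lies beyond the scatter of this kind of measurement.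

Compound 3, `Cc1cc(C(=O)n2c(C)c(CC(=O)O)c3cc(F)ccc32)c(C)cc1OC[C@@H]1CN(C)c2ccccc2O1`, has not yet been measured. It differs from compound 2 in one place: methyl in place of hydrogen on an aromatic carbon. Going by the values given here, no step between measured compounds shows what such a change does here, so the direction is open. A moderate change in either direction, not far beyond the scatter, is expected, with a 1.7-fold lower number from compound 2 to compound 3 (0.23 log units; within the scatter) as the estimated step. Compound 3 is expected to give about 35 nM in this assay, within a range from 8 nM to 150 nM.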

Compound 3, inhibition constant: 14 nM
Compound 3: the middle estimate sits 2.5-fold (0.40 log units) above what was measured; the range from low to high includes it.
By their numbers in this assay, from the lowest: compound 1; then compound 3; then compound 2.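

In this assay, a methyl in place of hydrogen on an aromatic carbon, ortho to a large group and para to a methyl group, gives a 4.2-fold lower number from compound 2 to compound 3 (0.62 log units; beyond the scatter), so one added carbon at this position strengthens binding beyond the scatter. The same kind of swap at another carbon of this ring goes the opposite way, with a 5.2-fold higher number from compound 1 to compound 3 (0.71 log units; beyond the scatter), also beyond the scatter, so the direction of this change depends on where on the ring the methyl sits. Nothing measured here explains why either step goes the way it does.

Going by these compounds, whether a chlorine atom, a methoxy group or a longer chain such as ethyl at the same carbon would lower the number further remains open. So does whether either step would hold on a different core.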